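Pyridin-3-yl in Place of Pyridin-2-yl

A few compounds are considered here, and "the series" means these few. Any claim that something is new, unique, unknown or untested is made for them only; others in the source may bear on it.

Among the compounds with values here, in an ADME assay (liver) for metabolic stability, with Liver microsome (Rattus norvegicus) as the target, using microsomes (a lower number here means slower removal, a higher number faster removal of the compound), compound 1 `c1ccc(CNc2nnc(-c3c[nH]c4ncccc34)o2)cc1` gives 40 mL.min-1.g-1 and compound 2 `c1ccc(CNc2nnc(-c3c[nH]c4ncccc34)o2)nc1` gives 14 mL.min-1.g-1, the lower of the two numbers so far. Compound 3 `c1cncc(CNc2nnc(-c3c[nH]c4ncccc34)o2)c1` has not yet been measured. It carries pyridin-3-yl in place of pyridin-2-yl on a saturated chain carbon bound to a nitrogen on an aromatic ring. Within the data shown here, only one measured step bears on this change, the modest one at the same place, with pyridin-2-yl in place of phenyl: a 2.9-fold lower number from compound 1 to compound 2 (0.46 log units; beyond the scatter). Among the measured compounds shown here, no measured step joins the two pyridinyl groups, so that step serves only as a rough upper guide to size. A small shift towards a higher number in this assay is expected, though not one beyond the scatter, and the estimate is a 1.4-fold higher number from compound 2 to compound 3 (0.15 log units; within the scatter). For compound 3 the estimated value is 20 mL.min-1.g-1, with an expected range from 9 mL.min-1.g-1 to 42 mL.min-1.g-1.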

Compound 3, intrinsic clearance in microsomes: 30 mL.min-1.g-1
Estimate against measurement, compound 3: 1.5-fold (0.18 log units) below; measured number inside the range.
By their numbers in this assay, from the lowest: compound 2; then compounds 3 and 1 (each within the scatter of the next).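

In this assay, the position on a saturated chain carbon bound to a nitrogen on an aromatic ring responds to which pyridinyl group sits there, not only to a pyridinyl group replacing phenyl: the change to pyridin-3-yl gives a 2.1-fold higher number from compound 2 to compound 3 (0.33 log units; beyond the scatter). With phenyl as the starting point, the same group gives a 1.3-fold lower number from compound 1 to compound 3 (0.12 log units; within the scatter), so among these three compounds the lower number belongs to pyridin-2-yl alone and not to pyridinyl groups in general. No evidence is available on why the two pyridinyl groups differ in this assay.

The compounds shown leave open where pyridin-4-yl would fall in this series. They also do not show whether a longer chain in place of the (pyridin-2-yl)methyl group would keep the number of compound 2.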